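A few compounds are considered here, and "the series" means these few. Any claim that something is new, unique, unknown or untested is made for them only; others in the source may bear on it.

Series notes: compounds bearing the shared core of compound 1 `O=C1CSC(c2cccc(O)c2)N1CCN1CCCCC1` in an ADME assay on Vero cells (Chlorocebus sabaeus) for cytotoxicity, read by neutral red uptake, tested at 394 ug/mL; on this read-out lower numbers stand for a stronger effect and higher numbers for a weaker effect at the one concentration tested. Of the compounds shown here, two have numbers so far. Compound 1 gives 100% in this assay. Compound 2 `COc1cccc(C2SCC(=O)N2CCN2CCCCC2)c1`, which carries a methyl in place of hydrogen on an oxygen on an aromatic ring, gives 57%. Among the compounds with values here, the one measured step is a number 43 percentage points lower from compound 1 to compound 2 (beyond the scatter), so compound 1 stands as the higher of the two numbers and compound 2 as the nearest, well beyond the scatter.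

Compound 3 `O=C1CSC(c2ccc(Cl)cc2)N1CCN1CCCCC1` is not yet measured in this assay. It differs from compound 1 as follows: 4-chlorophenyl in place of 3-hydroxyphenyl on a saturated ring carbon. Within the data shown here, the only step that bears on it is the one from compound 1 to compound 2, which shows that removing the hydrogen-bond donor from the 3-hydroxyphenyl moved the number far downward; the change to 4-chlorophenyl likewise removes that donor and the acceptor. The expectation is therefore a downward step beyond the scatter, roughly a number 35 percentage points lower from compound 1 to compound 3 (beyond the scatter), though the new group is a different one and the size is uncertain. For compound 3 the estimated value is 65%, with a range of 35% to 95%.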

Compound 3, a percentage reported as activity, at one concentration (the size of the read-out at that concentration, not a potency): 28%
Beside the measured number, compound 3's estimate is 37 percentage points above it; the whole stated range lies above it.
By their numbers in this assay, from the lowest: compound 3; then compound 2; then compound 1.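

In this assay, the aryl group on the saturated ring carbon carries the read-out a long way even when the heavy-atom count of the group stays the same, with a number 72 percentage points lower from compound 1 to compound 3 (beyond the scatter) for 4-chlorophenyl in place of 3-hydroxyphenyl. Losing the hydroxyl hydrogen does not by itself fix the number, since compound 2 gives 57% and compound 3 gives 28% with neither group retaining that hydrogen, so the nature of the group that replaces 3-hydroxyphenyl also matters at this position. Nothing at hand explains the size of this step or why the two compounds without the hydroxyl hydrogen differ.

Compound 3 changes both the substituent and its place on the aromatic ring, so the shown compounds cannot separate the effect of chlorine from the effect of where it sits. Unsubstituted phenyl, 3-chlorophenyl and 4-hydroxyphenyl on the same saturated ring carbon would pull these apart, and it remains open whether the read-out falls further with a group such as 4-bromophenyl or 3,4-dichlorophenyl.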